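This account rests on a few compounds, and the source may have more. Where it says the series, first, only, none or still open, it means among the compounds named here.

Measured in an assay on CHO-K1 cells for displacement of a labelled ligand from prostaglandin E2 receptor EP1 subtype (Homo sapiens), read by scintillation counting, with a stated time of 45 min; a higher number here means a weaker inhibitor, a lower number a stronger inhibitor:

- compound 1 `Cc1cc(C(=O)O)nn1Cc1cc(Cl)cc2cc(C3CCCCC3)oc12`: 3.98 nM
- compound 2 `CO[C@H]1CC[C@H](NC(=O)c2cc(C)n(Cc3cc(Cl)cc4cc(C(C)C)oc34)n2)CC1`: 316 nM
- compound 3 `Cc1cc(C(=O)NN2CCOCC2)nn1Cc1cc(Cl)cc2cc(-c3ccccc3)oc12`: 10 nM

Compound 3 holds the second highest of the three numbers. Its nearest neighbour is compound 1, whose number is lower, with a gap that lies beyond the usual scatter; its furthest is compound 2, whose number is far higher, again well beyond the scatter. Among the measured compounds shown here, no two of the measured compounds differ in a single place, so no single-point step is available to calibrate the change considered next.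

Compound 4 `Cc1cc(C(N)=O)nn1Cc1cc(Cl)cc2cc(-c3ccccc3)oc12` is not yet measured. It differs from compound 3 in one place: hydrogen in place of morpholin-4-yl on an amide-type nitrogen. What remains on the carbonyl is a plain carbamoyl group, which, among the measured compounds, sits nearest in kind to the acid of compound 1 and far from the substituted amide of compound 2.

For the measured compounds named here, with no matching step to lean on, the expected change from compound 3 to compound 4 is a 2.0-fold higher number from compound 3 to compound 4 (0.30 log units; within the scatter), a modest shift toward a higher number or none beyond the scatter. Compound 4 is therefore estimated at 20 nM, within a range from 5 nM to 80 nM.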

Compound 4, half-maximal inhibitory concentration: 5.01 nM
The estimate for compound 4 lay 4.0-fold (0.60 log units) above the measured number; low and high end bracket the measured number.
By their numbers in this assay, from the lowest: compounds 1, 4 and 3 (each within the scatter of the next, the first and the last beyond it); then compound 2.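

In this assay, among the compounds shown here, the only single-place step reads a 2.0-fold lower number from compound 3 to compound 4 (0.30 log units; within the scatter), so on this amide-type nitrogen, morpholin-4-yl and hydrogen cannot be told apart on the core of compound 3. The whole morpholin-4-yl group, with its 6 heavy atoms and its six-membered non-aromatic ring, can therefore give way to a single hydrogen without a step beyond the scatter, a statement that holds for this one pair alone. Nothing at hand bears on the reason for this result.

Compound 1 and compound 2 each differ from compound 4 in more than one place, so their steps to it cannot be read, and the separate contributions of the carbonyl substituent and of the other varied group remain unresolved. Still open, on these data alone, is whether this tolerance extends to other groups on the same nitrogen, such as a methyl group, a longer alkyl chain or a piperidin-1-yl ring, and whether a carboxylic acid in place of the carbamoyl group on the core of compound 4 would give a step beyond the scatter.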